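Ethyl for Phenyl on the Ring Nitrogen

The source may report more compounds than this note shows. Statements on the series, on what has been measured and on what is new or still open speak of the compounds shown alone.

Measured in a functional assay on the whole organism (strain albino) for inhibition, with Rattus norvegicus as the target, read by paw edema, with stated times of 30 min and 5 h, at a dose of 0.28 mmol/kg by the oral route; a higher number here means more inhibition at the dose given (going by the name of the read-out), a lower number less inhibition:
compound 1 `C/C(=N\O)c1ccc(NC(=O)CSc2nnc(-c3ccccc3)n2-c2ccccc2)cc1`: 66%
compound 2 `COc1ccc(-c2nnc(SCC(=O)Nc3ccc(/C(C)=N/O)cc3)n2-c2ccccc2)cc1`: 58%
compound 3 `COc1ccc(-c2nnc(SCC(=O)Nc3ccc(/C(C)=N/O)cc3)n2-c2ccccc2)cc1OC`: 76%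

Compound 1 stands second highest of the three numbers. Its nearest neighbour is compound 2, a number 8 percentage points lower from compound 1 to compound 2 (within the scatter); its furthest is compound 3, a number 10 percentage points higher from compound 1 to compound 3 (within the scatter). Between the other two, a number 18 percentage points higher from compound 2 to compound 3 (beyond the scatter).

Compound 4 `CCn1c(SCC(=O)Nc2ccc(/C(C)=N/O)cc2)nnc1-c1ccccc1` differs from compound 1 in one place: ethyl in place of phenyl on an aromatic nitrogen. All three measured steps alter the group on the aromatic carbon and leave the aromatic nitrogen untouched, so none of them bears directly on this change. In this assay, the step from compound 1 to compound 4 is therefore expected to be a number 6 percentage points lower from compound 1 to compound 4 (within the scatter), none beyond the scatter. Compound 4 is estimated at 60%, with a range from 45% to 75%.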

Compound 4, a percentage reported as inhibition, in the whole organism at one dose (the size of the read-out at that dose, not a potency): 66%
Compound 4: the middle estimate sits 6 percentage points below what was measured; the range from low to high includes it.
By their numbers in this assay, from the lowest: compounds 2, 1, 4 and 3 (each within the scatter of the next, the first and the last beyond it).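

In this assay, within the data shown here, ethyl in place of phenyl on the aromatic nitrogen gives no change at the digits printed from compound 1 to compound 4 (within the scatter) and so provides a reading at this position, which the earlier steps on the aromatic carbon could not. At this one dose, the ring nitrogen carries ethyl, with 2 heavy atoms and no ring, and phenyl, with 6 heavy atoms, without a difference in the read-out. Nothing on hand explains this result.

As far as these compounds go, whether a longer chain such as butyl, or a benzyl group, would give the same reading on this nitrogen remains open. From the compounds shown here alone, it is also open whether ethyl would do so alongside the methoxy group of compound 2 or the 3,4-dimethoxyphenyl group of compound 3.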